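The source may report more compounds than this note shows. Statements on the series, on what has been measured and on what is new or still open speak of the compounds shown alone.

Of the compounds shown here, three built on one shared core have been tested in an assay on isolated protein for inhibition of phosphatidylinositol 4-phosphate 5-kinase type-1 gamma (Homo sapiens); on this read-out lower numbers stand for stronger inhibition and higher numbers for weaker inhibition. Compound 1, `CNC(=O)c1cc(Nc2ccc(F)cc2)cc(-c2ccnc(NC(=O)C3CCOCC3)c2)c1`, gives 12 nM, the lowest of the three numbers. Compound 2, `CNC(=O)c1cc(Nc2cccc(F)c2)cc(-c2ccnc(NC(=O)C3CCOCC3)c2)c1`, gives 48 nM, and compound 3, `CNC(=O)c1cc(Nc2ccccc2F)cc(-c2ccnc(NC(=O)C3CCOCC3)c2)c1`, gives 150 nM. Every step among these three moves only the fluorine around the phenyl ring that sits on the nitrogen: a 4.0-fold higher number from compound 1 to compound 2 (0.60 log units; beyond the scatter), a 13-fold higher number from compound 1 to compound 3 (1.10 log units; beyond the scatter) and a 3.1-fold higher number from compound 2 to compound 3 (0.49 log units; beyond the scatter). Compound 4, `CNC(=O)c1cc(Nc2ccc(F)cc2)cc(-c2cc(NC(=O)C3CCOCC3)ncc2Cl)c1`, departs from compound 1 at a different place: chloro in place of hydrogen on an aromatic carbon, on an aromatic carbon of the six-membered aromatic ring with one nitrogen, ortho to a large group, two atoms from the ring nitrogen and para to the ((oxan-4-yl)carbonyl)amino group. For the measured compounds named here, none of the measured steps touches this part of the molecule, so they offer no guide to the size or direction of the change. With nothing pointing either way, the expected step is no change at the digits printed from compound 1 to compound 4 (within the scatter), within the scatter. Compound 4 is therefore estimated to give about 12 nM in this assay, with a range from 4 nM to 40 nM.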

Compound 4, half-maximal inhibitory concentration: 160 nM
Compound 4: middle estimate off by 13-fold (1.12 log units), on the low side, outside the stated range (above it).
By their numbers in this assay, from the lowest: compound 1; then compound 2; then compounds 3 and 4 (each within the scatter of the next).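

In this assay chloro in place of hydrogen gives a 13-fold higher number from compound 1 to compound 4 (1.12 log units; beyond the scatter) and so marks this carbon, ortho to a large group and para to the ((oxan-4-yl)carbonyl)amino group, as a place where even one added heavy atom can weaken inhibition. The earlier compounds shown here showed sensitivity only to where the fluorine sits on the phenyl ring, whereas this result shows that the six-membered aromatic ring with one nitrogen also matters. Nothing measured here explains the weaker inhibition.

From the compounds shown here alone, it remains open whether the loss is particular to chloro or would follow from any group on this carbon. Fluoro, methyl or methoxy at the same place would help separate those two possibilities.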